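Chloro for hydrogen on the pendant phenyl of compound 2

A few compounds are considered here, and "the series" means these few. Any claim that something is new, unique, unknown or untested is made for them only; others in the source may bear on it.

Compound 1 `COc1ccc2c(c1)OC(c1ccc([N+](=O)[O-])cc1)C(c1ccccc1)C2=O` and compound 2 `CCOc1ccc2c(c1)OC(c1ccccc1)C(c1ccccc1)C2=O` share the core, and compound 3 `CCOc1ccc2c(c1)OC(c1ccc(Cl)cc1)C(c1ccccc1)C2=O` has not yet been measured. In a functional assay on HL-60 cells (Homo sapiens) for cytotoxicity, read by MTT assay, with a stated time of 5 days (a higher number here means that more compound is tolerated, a lower number that less compound is tolerated), compound 1 gives 73200 nM. Compound 2 gives > 2500000 nM, which is a limit of the assay rather than a number. Compound 2 thus sits at the limit of > 2500000 nM in this assay, at which 1 of the 2 values shown sits, so its position on the scale is known only as a floor, not as a point. Within the data shown here, no step between measured compounds is available here, and the two values of compound 1 and compound 2 show only that they differ in more than one place. Compound 3 differs from compound 2 by chloro in place of hydrogen on an aromatic carbon. For this change the expected direction is toward lower values, beyond the scatter, with an estimated step of an at least 5.0-fold lower number from compound 2 to compound 3 (0.69 log units; beyond the scatter). Compound 3 is expected to give about 500000 nM, with a likely range from 50000 nM to 2500000 nM. If compound 3 also returns only a limit, the step will remain unquantified.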

Compound 3, half-maximal cytotoxic concentration: 514000 nM
For compound 3 the middle estimate is 1.0-fold (0.01 log units) below the measured one, and the stated range covers the measured number.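

In this assay, among these compounds, the change from phenyl to 4-chlorophenyl provides the first step that can be read at a single place: an at least 4.8-fold lower number from compound 2 to compound 3 (0.68 log units; beyond the scatter). The aromatic carbon para to a large group is therefore a position where replacing hydrogen with chloro changes the read-out beyond the scatter, and compound 3 gives the ethoxy series a point on the scale rather than a floor. The true size of the step remains open, since the value of compound 2 is a limit and not a number: the limit of > 2500000 nM in this assay, at which 1 of the 3 values shown sits.

Compound 1 differs from compound 3 in more than one place, so the compounds shown do not separate the contribution of its nitro group from that of its methoxy group. On these data alone, how an amine or a carboxylic acid at the same position would compare with chloro also remains open.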